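Sulfonamide series: silyl-alkyne to alkenyl chain step

The source may hold more compounds than are shown below. What is called first, only, known or untested is meant among the compounds shown, and "the series" means these compounds.

Measured so far:
compound 1 `CCCCC#Cc1ccc(S(=O)(=O)Nc2cccc(-c3csc(NC(C)=O)n3)c2)cc1` — 73.2%
compound 2 `CC(=O)Nc1nc(-c2cccc(NS(=O)(=O)c3ccc(C#C[Si](C)(C)C)cc3)c2)cs1` — 94.3%

In a functional assay on A-375 cells (Homo sapiens) for antiproliferative activity, read by trypan blue exclusion, with a stated time of 48 h, tested at 1 uM (a lower number here means a stronger effect, a higher number a weaker effect of the compound at the concentration tested), compound 2 gives 94.3%, the highest of the two numbers. Compound 1 gives 73.2%. For the measured compounds named here, the only step measured so far, a number 21.1 percentage points higher from compound 1 to compound 2 (beyond the scatter), runs from a four-carbon chain on the triple-bonded carbon to the silicon-bearing group.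

Compound 3 `CCCCCC/C=C\c1ccc(S(=O)(=O)Nc2cccc(-c3csc(NC(C)=O)n3)c2)cc1` is not yet measured. It differs from compound 2 as a group of 8 heavy atoms (8 carbon; no ring) in place of a group of 6 heavy atoms (5 carbon, 1 silicon; no ring), on an aromatic carbon. Going by the values given here, the entering group is a carbon chain of 8 heavy atoms with 1 double bond outside aromatic rings, so the change broadly reverses the direction of the one step in hand, though the chain is longer and the triple bond is gone, which nothing measured covers.

The step of a number 21.1 percentage points higher from compound 1 to compound 2 (beyond the scatter) is therefore the only bearing on this case, and a move of comparable size back toward the number of compound 1 is expected, with a lower number for compound 3. Compound 3 is estimated at 76%, within 58% to 94%. The expected step is a number 18.3 percentage points lower from compound 2 to compound 3 (beyond the scatter).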

Compound 3, a percentage reported as activity, at one concentration (the size of the read-out at that concentration, not a potency): 48.8%
Estimate against measurement, compound 3: 27.2 percentage points above; the whole stated range lies above it.
By their numbers in this assay, from the lowest: compound 3; then compound 1; then compound 2.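

In this assay, the carbon chain with 1 double bond outside aromatic rings gives the strongest effect of the three compounds, with a number 45.5 percentage points lower from compound 2 to compound 3 (beyond the scatter) and a number 24.4 percentage points lower from compound 1 to compound 3 (beyond the scatter) as the steps. Replacing the silicon-bearing group at this position, on an aromatic carbon para to a large group, therefore does more than return the number to the level of compound 1, so the all-carbon chains in compound 1 and compound 3 are not equivalent. No measurement at hand explains this change.

Chain length and the replacement of the triple bond by a double bond change together between compound 1 and compound 3, so their separate contributions remain unresolved. A saturated octyl chain, the trans double-bond isomer or a terminal amine on the chain would test how far this trend extends.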